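The source may hold more compounds than are shown below. What is called first, only, known or untested is meant among the compounds shown, and "the series" means these compounds.

Of the compounds shown here, three sharing one core have been measured in a functional assay on A549 cells (Homo sapiens) for cytotoxicity, read by MTT assay, with a stated time of 72 h; a higher number here means a weaker inhibitor, a lower number a stronger inhibitor. Compound 1 `c1ccc(NN=C(c2nc3ccccc3[nH]2)c2nc3ccccc3[nH]2)cc1` gives 3800 nM. Compound 2 `Cc1ccc(NN=C(c2nc3ccccc3[nH]2)c2nc3ccccc3[nH]2)cc1` gives 600 nM, and compound 3 `COc1ccc(NN=C(c2nc3ccccc3[nH]2)c2nc3ccccc3[nH]2)cc1` gives 500 nM, the lowest of the three numbers, although its gap to compound 2 lies within the scatter, so the two cannot be ranked. The clear step is a 7.6-fold lower number from compound 1 to compound 3 (0.88 log units; beyond the scatter). Compound 4 `Clc1ccc(NN=C(c2nc3ccccc3[nH]2)c2nc3ccccc3[nH]2)cc1` differs from compound 3 by chloro in place of methoxy on an aromatic carbon. Within the data shown here, two measured steps bear on this change: a 6.3-fold lower number from compound 1 to compound 2 (0.80 log units; beyond the scatter) and a 7.6-fold lower number from compound 1 to compound 3 (0.88 log units; beyond the scatter) show two different groups in the same place lowering the number by a similar amount, while a 1.2-fold lower number from compound 2 to compound 3 (0.08 log units; within the scatter) shows the two groups hardly differ. A chloro group is therefore expected to give a number close to that of compound 3, and a 1.1-fold higher number from compound 3 to compound 4 (0.04 log units; within the scatter) is expected to stay within the scatter. Compound 4 is estimated at 550 nM, between 180 nM and 1700 nM.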

Compound 4, half-maximal inhibitory concentration: 2800 nM
Compound 4: middle estimate off by 5.1-fold (0.71 log units), on the low side, outside the stated range (above it).
By their numbers in this assay, from the lowest: compounds 3 and 2 (each within the scatter of the next); then compounds 4 and 1 (each within the scatter of the next).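

In this assay the place on the aromatic ring does not reward every group alike: chloro in place of methoxy gives a 5.6-fold higher number from compound 3 to compound 4 (0.75 log units; beyond the scatter) and chloro in place of methyl gives a 4.7-fold higher number from compound 2 to compound 4 (0.67 log units; beyond the scatter) while chloro in place of hydrogen gives only a 1.4-fold lower number from compound 1 to compound 4 (0.13 log units; within the scatter). Among these four compounds, then, methyl and methoxy share the lower numbers, and chloro does not join them. Nothing measured here explains this split. Going by these compounds, whether other groups at this place, such as an amine, a carboxylic acid or a longer chain, would fall with methyl and methoxy or with chloro remains open.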